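Taking the allyl group off compound 2

A few compounds are considered here, and "the series" means these few. Any claim that something is new, unique, unknown or untested is made for them only; others in the source may bear on it.

Compound 1 `C#CCOc1ccc(C(=O)Nc2cc3ccc(OC4CCN(C)CC4)c(C)c3oc2=O)cc1CC=C(C)C`: 1400 nM
Compound 2 `C=CCc1cc(C(=O)Nc2cc3ccc(OC4CCN(C)CC4)c(C)c3oc2=O)ccc1OC(C)=O`: 2260 nM

In a functional assay on SK-BR-3 cells (Homo sapiens) for antiproliferative activity (a higher number here means a weaker inhibitor, a lower number a stronger inhibitor), compound 2 gives 2260 nM, which lies within the scatter of compound 1 at 1400 nM. With only these two numbers, neither can be ranked above the other. Compound 3 `CC(=O)Oc1ccc(C(=O)Nc2cc3ccc(OC4CCN(C)CC4)c(C)c3oc2=O)cc1` differs from compound 2 in one place: hydrogen in place of allyl on an aromatic carbon. For the measured compounds named here, no measured pair shows this change on its own, so the data give no direct guide to its size. A modest weakening in this assay is expected, meaning a somewhat higher number, though a result within the scatter would not surprise. The expected change is a 1.5-fold higher number from compound 2 to compound 3 (0.19 log units; within the scatter). For compound 3 the estimated value is 3500 nM, with an expected range from 1400 nM to 10000 nM.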

Compound 3, half-maximal inhibitory concentration: 1670 nM
Compound 3: the middle estimate sits 2.1-fold (0.32 log units) above what was measured; the range from low to high includes it.
By their numbers in this assay, from the lowest: compounds 1, 3 and 2 (each within the scatter of the next).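

In this assay the change from allyl to hydrogen on the aromatic carbon ortho to the acetoxy group gives a 1.4-fold lower number from compound 2 to compound 3 (0.13 log units; within the scatter) and so cannot be told apart from no change. For the compounds shown here, this is the first direct reading of this position: the allyl group, with its 3 heavy atoms and its double bond, can be removed without a shift beyond the scatter, so activity at this level does not depend on it while the acetoxy group stays in place. Nothing measured here accounts for this result.

The compounds shown leave open whether a different group on this carbon, such as an amine, a carboxylic acid or a fluorine atom, would move the number beyond the scatter. They also leave open whether removing the allyl group would have as small an effect with a hydroxyl group in place of the acetoxy group.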